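The source may hold more compounds than are shown below. What is called first, only, known or untested is meant among the compounds shown, and "the series" means these compounds.

Working notes on the series. In a physicochemical assay for lipophilicity, at pH 7.4 (a lower number here means a more polar compound, a higher number a more lipophilic compound), compound 1 `Cc1cc(C(=O)NC(C)C)nn1Cc1cc(Cl)ccc1OCc1ccccc1` gives > 3.7, which is a limit of the assay and not a number. Among the measured compounds shown here, compound 2 `Cc1cc(NC(=O)C2CCCC2)nn1Cc1cc(Cl)ccc1OCc1ccccc1` gives 3.5, the only true number so far. Compound 3 `Cc1cc(NC(=O)C2CCCO2)nn1Cc1cc(Cl)ccc1OCc1ccccc1` departs from compound 2 by one change: oxolan-2-yl in place of cyclopentyl on a carbonyl carbon. For the measured compounds named here, the only measured step, a number at least 0.20 log units lower from compound 1 to compound 2 (that floor lies within the scatter), concerns a different change on an aromatic carbon, so it gives no direct measure for this swap. The estimate therefore rests on compound 2 at 3.5 and on the hydrogen-bond acceptor counted in the entering oxolan-2-yl. A fall in this assay beyond the scatter is expected. The expected change is a number 0.90 log units lower from compound 2 to compound 3 (beyond the scatter). Compound 3 is estimated at 2.6, with an expected range of 2.1 to 3.1.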

Compound 3, distribution coefficient: > 3.7
Compound 3: only a limit was reported; the forecaster's own chance of this, stated with the estimate: 3%; at least 1.10 log units between middle value and limit.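

In this assay compound 3 gives > 3.7, which is a limit of the assay and not a number. On a carbonyl carbon, oxolan-2-yl in place of cyclopentyl gives a number at least 0.20 log units higher from compound 2 to compound 3 (that floor lies within the scatter), so at this place the entering hydrogen-bond acceptor comes with no measured fall, though the floor of the step does not clear the scatter. The true size of the step stays unknown because compound 3 reads only as a limit: the limit of > 3.7 in this assay, at which 2 of the 3 values shown sit.

The step from compound 1 to compound 3 cannot be read, as the two limits leave it without a size. Still open, going by these compounds, is whether a group carrying an amine or a carboxylic acid in place of oxolan-2-yl would give a true number in this assay.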